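A few compounds are considered here, and "the series" means these few. Any claim that something is new, unique, unknown or untested is made for them only; others in the source may bear on it.

Compound 1, `COc1cc2ncnc(Nc3ccc(F)cc3)c2cc1OCCCCC(=O)Nc1ccc(S(N)(=O)=O)cc1`, is measured in a functional assay on NCI-H1975 cells (Homo sapiens) for antiproliferative activity, read by MTT assay, with a stated time of 72 h (on this read-out higher numbers stand for weaker inhibition and lower numbers for stronger inhibition), and reaches only the assay limit, > 40000 nM. Compound 2, `COc1cc2ncnc(Nc3ccccc3)c2cc1OCCCCC(=O)Nc1ccc(S(N)(=O)=O)cc1`, is a closer relative in which the change hydrogen in place of fluoro on an aromatic carbon has been made; in this assay compound 2 gives 14100 nM. The resulting step, an at least 2.8-fold lower number from compound 1 to compound 2 (0.45 log units; beyond the scatter), can be stated only as a lower bound because the limit of > 40000 nM in this assay, at which 1 of the 3 values shown sits, sits at the starting point of that comparison.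

Compound 3, `NS(=O)(=O)c1ccc(NC(=S)Nc2ccc3ncnc(Nc4ccc(F)c(Br)c4)c3c2)cc1`, is built on a different core, and the difference between the two cores is not broken down here. In this assay compound 3 gives 9980 nM, which is within the scatter of compound 2.

Compound 4, `NS(=O)(=O)c1ccc(NC(=S)Nc2ccc3ncnc(Nc4cccc(Br)c4)c3c2)cc1`, is not yet measured. It differs from compound 3 by hydrogen in place of fluoro on an aromatic carbon. Going by the values given here, this is the same kind of change as the one from compound 1 to compound 2, but not the same: in compound 3 the fluoro sits ortho to a bromo group and para to a large group, whereas in compound 1 it sits only para to a large group, and the cores carrying the change differ as well. Among the compounds with values here, since the one measured instance of this change, an at least 2.8-fold lower number from compound 1 to compound 2 (0.45 log units; beyond the scatter), gave a lower number, a lower number is also expected for compound 4, though a smaller one given the different surroundings; the estimated step is a 1.7-fold lower number from compound 3 to compound 4 (0.22 log units; within the scatter). Compound 4 is therefore expected to give about 6000 nM in this assay, most likely between 2500 nM and 15000 nM.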

Compound 4, half-maximal inhibitory concentration: 11000 nM
Estimate against measurement, compound 4: 1.8-fold (0.26 log units) below; low and high end bracket the measured number.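

On the core of compound 3, hydrogen in place of fluoro gives in this assay a 1.1-fold higher number from compound 3 to compound 4 (0.04 log units; within the scatter). Set beside the earlier step on the core of compound 1, this shows that the size of the effect did not carry over from one core to the other in this series: the same change on two cores in this assay, an at least 2.8-fold lower number (0.45 log units; beyond the scatter) from compound 1 to compound 2 and a 1.1-fold higher number (0.04 log units; within the scatter) from compound 3 to compound 4, at least 3.1-fold (0.49 log units) apart, beyond the scatter of two such steps

It does not show that the core alone sets the outcome, since each core offers a single pair, only the pair on the core of compound 3 carries a bromo group on the same ring as the fluoro, and the earlier step is known only as a bound, with compound 1 standing at an assay limit: the limit of > 40000 nM in this assay, at which 1 of the 4 values shown sits.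

The compounds shown leave open whether the fluoro would count for more on the core of compound 3 if a chloro or a methyl group stood in place of the bromo group, and whether the pair on the core of compound 1 would behave like the later pair once a bromo group was added to its phenyl ring. They also leave open how the change would read with a shorter or longer chain linking the core to the benzenesulfonamide, or with a carboxylic acid in place of the sulfonamide.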